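Lengthening the Ester Side Chain of Compound 2

The source may hold more compounds than are shown below. What is called first, only, known or untested is meant among the compounds shown, and "the series" means these compounds.

For the measured compounds named here, compound 2 `COC(=O)C[C@@H](NC(=O)Cn1cc(C2=C(c3c[nH]c4ccccc34)C(=O)N(C)C2=O)c2ccccc21)C(=O)OC` gives 74200 nM in a functional assay on A549 cells (Homo sapiens) for cytotoxicity, read by MTT assay, with a stated time of 24 h (a lower number here means a stronger inhibitor, a higher number a weaker inhibitor), the top of the two numbers measured so far, though its gap to compound 1 `COC(=O)CCNC(=O)Cn1cc(C2=C(c3c[nH]c4ccccc34)C(=O)N(C)C2=O)c2ccccc21`, which gives 37600 nM, lies within the scatter: a 2.0-fold higher number from compound 1 to compound 2 (0.30 log units; within the scatter). Compound 3 `COC(=O)CC[C@@H](NC(=O)Cn1cc(C2=C(c3c[nH]c4ccccc34)C(=O)N(C)C2=O)c2ccccc21)C(=O)OC` is not yet measured and differs from compound 2 by (methoxycarbonyl)methyl in place of methoxycarbonyl on a saturated chain carbon, two bonds along the chain from an amide-type nitrogen and a carbonyl carbon. Going by the values given here, the single measured step, which placed a methoxycarbonyl group on the same chain, bears only loosely on this change and stayed within the scatter, so no step beyond the scatter is expected in this assay. Compound 3 is estimated at 74000 nM, within 30000 nM to 180000 nM. The expected step is a 1.0-fold lower number from compound 2 to compound 3 (0.00 log units; within the scatter).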

Compound 3, half-maximal inhibitory concentration: 73700 nM
Compound 3: middle estimate off by 1.0-fold (0.00 log units), on the high side; the range from low to high includes it.
By their numbers in this assay, from the lowest: compounds 1, 3 and 2 (each within the scatter of the next).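

In this assay, (methoxycarbonyl)methyl in place of methoxycarbonyl on this saturated chain carbon gives a 1.0-fold lower number from compound 2 to compound 3 (0.00 log units; within the scatter), so this extension of the ester side chain does not separate compound 2 from compound 3. 1,3-bis(methoxycarbonyl)propyl in place of 2-(methoxycarbonyl)ethyl on the amide-type nitrogen gives a 2.0-fold higher number from compound 1 to compound 3 (0.29 log units; within the scatter), which leaves all three compounds within the scatter of one another. No measurement at hand explains these numbers. On these data alone, it stays open whether a carboxylic acid in place of the methyl esters, an amine, or a longer chain on this carbon would give a step beyond the scatter.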